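The compounds below may be only part of what the source reports. "The series", "measured", "known", "first", "only" and "open" are said of these compounds alone.

For the measured compounds named here, in a functional assay, read by spectrophotometry, with a stated time of 30 min (on this read-out higher numbers stand for weaker inhibition and lower numbers for stronger inhibition), compound 3 (`CCOC(=O)[C@H](C)NC(=O)/C=C/c1ccc(O)c(OC)c1`) gives 46400 nM, the only true number so far. Compound 1 (`COc1cc(/C=C/C(=O)O)ccc1OC(C)=O`) reads > 500000 nM in this assay, which is a limit of the assay and not a number. Compound 2 (`CCOC(=O)[C@@H](NC(=O)/C=C/c1ccc(OC(C)=O)c(OC)c1)C(C)C`) reads > 500000 nM, again a limit and not a number.

Compound 4 (`CCOC(=O)[C@H](C)NC(=O)/C=C/c1ccc(OC(C)=O)c(OC)c1`) is compound 3 with hydroxy turned to acetoxy, the difference being acetyl in place of hydrogen on an oxygen on an aromatic ring and nothing else. Going by the values given here, no measured pair isolates this change, so the expectation rests on thin ground: compound 1 and compound 2 both carry acetoxy and both meet (the limit of > 500000 nM in this assay, at which 2 of the 3 values shown sit), while compound 3 carries hydroxy. A clear step towards weaker inhibition is therefore expected, and the estimated move is an 8.6-fold higher number from compound 3 to compound 4 (0.94 log units; beyond the scatter) in this assay. For compound 4 the expected value is 400000 nM, with an estimated range of 150000 nM to 500000 nM, and a report of the limit alone is the more likely outcome.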

Compound 4, half-maximal inhibitory concentration: 482000 nM
The estimate for compound 4 lay 1.2-fold (0.08 log units) below the measured number, and the stated range covers the measured number.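

The change of hydroxy to acetoxy on this aromatic ring now has a measured size in this assay, where acetyl in place of hydrogen on an oxygen on an aromatic ring gives a large step, a 10-fold higher number from compound 3 to compound 4 (1.02 log units; beyond the scatter), with nothing else in the structure altered. The earlier compounds shown here offered no pair that isolated this change, whereas here the loss of inhibition can be assigned to this one position carrying the methyl side chain and ethyl ester. Compound 1 and compound 2 each stand at a limit of the assay and not at a number: the limit of > 500000 nM in this assay, at which 2 of the 4 values shown sit. Methyl in place of isopropyl on a saturated chain carbon bound to an amide-type nitrogen and a carbonyl carbon gives an at least 1.0-fold lower number from compound 2 to compound 4 (0.01 log units; that floor lies within the scatter), and (1-(ethoxycarbonyl)ethyl)amino in place of hydroxy on a carbonyl carbon gives an at least 1.0-fold lower number from compound 1 to compound 4 (0.01 log units; that floor lies within the scatter), so neither of these two steps shows a change in inhibition.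

On these data alone, whether an amine or a methoxy group on this ring position would keep the reading of compound 3 remains open. Also open, as far as these compounds go, is whether the same step holds with a carboxylic acid or an isopropyl side chain in the molecule.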